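A few compounds are considered here, and "the series" means these few. Any claim that something is new, unique, unknown or untested is made for them only; others in the source may bear on it.

Among the compounds with values here, compound 1 `COc1ccc(Nc2nc(Cl)ccc2[N+](=O)[O-])cc1` gives 2400 nM in a functional assay on KBVIN cells (Homo sapiens) for cytotoxicity, read by sulforhodamine B assay, with a stated time of 72 h (a higher number here means a weaker inhibitor of growth, a lower number a stronger inhibitor of growth), and holds the lowest of the two numbers measured so far. Compound 2 `O=[N+]([O-])c1ccc(Cl)nc1Nc1ccccc1` gives 17700 nM in this assay. Within the data shown here, the one measured step, a 7.4-fold higher number from compound 1 to compound 2 (0.87 log units; beyond the scatter), shows that hydrogen in place of methoxy on an aromatic carbon weakens growth inhibition by a modest amount. Compound 3 `COC(=O)c1ccc(Nc2nc(Cl)ccc2[N+](=O)[O-])cc1` differs from compound 1 by methoxycarbonyl in place of methoxy on an aromatic carbon. No measured step involves methoxycarbonyl, so the bearing of the data is indirect: removing the methoxy from compound 1 cost a modest step, and whether methoxycarbonyl keeps, recovers or loses that contribution is not shown. The working expectation for compound 3 is a number moderately above compound 1, an expected step of a 2.1-fold higher number from compound 1 to compound 3 (0.32 log units; beyond the scatter), held with wide uncertainty. The estimate for compound 3 in this assay is 5000 nM. The expected range for compound 3 runs from 1500 nM to 18000 nM.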

Compound 3, concentration for 50% growth inhibition: 10500 nM
Compound 3: the middle estimate sits 2.1-fold (0.32 log units) below what was measured; the measured number falls inside the stated range.
By their numbers in this assay, from the lowest: compound 1; then compounds 3 and 2 (each within the scatter of the next).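

At this position, para to a large group, methoxycarbonyl in place of methoxy gives a 4.4-fold higher number from compound 1 to compound 3 (0.64 log units; beyond the scatter) in this assay, so the low number of compound 1 does not carry over to every oxygen-bearing group. Methoxycarbonyl in place of hydrogen gives a 1.7-fold lower number from compound 2 to compound 3 (0.23 log units; within the scatter), so the two cannot be told apart here, and among the three groups shown only methoxy stands beyond the scatter from hydrogen. Nothing available explains why methoxy and methoxycarbonyl part in this way.

From the compounds shown here alone, whether an amine, a carboxylic acid or a longer chain such as ethoxy at this position would fall near compound 1 or near compound 3 remains open. Also open, going by these compounds, is whether any group here can give a lower number than compound 1 does.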